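This account rests on a few compounds, and the source may have more. Where it says the series, first, only, none or still open, it means among the compounds named here.

Compound 2, `COc1cccc(-c2noc(-c3ccc(C4=NCCN4)cc3)n2)c1`: 216 nM
Compound 1, `c1ccc(OCc2noc(-c3ccc(C4=NCCN4)cc3)n2)cc1`: 9980 nM

Going by the values given here, in an assay for inhibition of Amine oxidase [flavin-containing] B (Homo sapiens), read by fluorescence and spectrophotometry, using microsomes, with stated times of 30 min and 20 min (on this read-out lower numbers stand for stronger inhibition and higher numbers for weaker inhibition), compound 2 gives 216 nM, the lowest of the two numbers so far; the nearest is compound 1, which gives 9980 nM. Among the compounds with values here, the single measured step, a 46-fold lower number from compound 1 to compound 2 (1.66 log units; beyond the scatter), replaced a phenoxymethyl group by a 3-methoxyphenyl group, a different kind of change from the one now considered. Compound 3, `Clc1ccc(-c2noc(-c3ccc(C4=NCCN4)cc3)n2)cc1Cl`, differs from compound 2 by 3,4-dichlorophenyl in place of 3-methoxyphenyl on an aromatic carbon. Within the data shown here, no measured step exchanges one substituent on this directly attached six-membered ring for another, so that step offers little direct guidance; it shows only that changes at this position can move the number a long way. With both compounds keeping a directly attached ring, the expected step is small, a 1.4-fold lower number from compound 2 to compound 3 (0.16 log units; within the scatter), within the scatter. The estimate for compound 3 is 150 nM, with a range from 30 nM to 800 nM.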

Compound 3, half-maximal inhibitory concentration: 12 nM
Beside the measured number, compound 3's estimate is 13-fold (1.10 log units) above it; the whole stated range lies above it.
By their numbers in this assay, from the lowest: compound 3; then compound 2; then compound 1.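

In this assay, the 3,4-dichlorophenyl group in place of 3-methoxyphenyl gives an 18-fold lower number from compound 2 to compound 3 (1.26 log units; beyond the scatter) even though both groups hold the same number of heavy atoms and the same kind of ring. So what the attached ring carries matters here, and not only the presence of a directly attached ring, which was all the earlier step could suggest. Across the whole range at this position, 3,4-dichlorophenyl in place of phenoxymethyl gives an 830-fold lower number from compound 1 to compound 3 (2.92 log units; beyond the scatter) and no measurement shown explains the size of either step.

The step removes a methoxy group and adds two chlorine atoms at once, so the share of each remains unclear. Also open, from the compounds shown here alone, is how a phenyl ring with a single chlorine, or one carrying an amine or a carboxylic acid, would read.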